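Compound 3 to compound 4: methoxy for trifluoromethyl

The compounds below may be only part of what the source reports. "The series", "measured", "known", "first", "only" and "open" are said of these compounds alone.

Values in an ADME assay on L02 cells (Homo sapiens) for inhibition, read by CCK-8 assay, with a stated time of 48 h (a higher number here means a weaker inhibitor of growth, a lower number a stronger inhibitor of growth), are as follows
Compound 1 (`Cc1ccccc1Nc1nc(NCc2ccco2)ncc1Cl`) gives > 100000 nM as a limit of the assay
Compound 2 (`CN1CCN(c2ccc(Nc3ncc(Cl)c(Nc4ccccc4)n3)nc2)CC1`) gives 7990 nM
Compound 3 (`CN1CCN(c2ccc(Nc3ncc(Cl)c(NCc4ccc(C(F)(F)F)cc4)n3)nc2)CC1`) gives 26200 nM as well

Compound 3 (26200 nM) holds the highest of the two numerical values. Compound 4 (`COc1ccc(CNc2nc(Nc3ccc(N4CCN(C)CC4)cn3)ncc2Cl)cc1`) carries methoxy in place of trifluoromethyl on an aromatic carbon, para to a large group (methoxy in place of trifluoromethyl on an aromatic carbon). Within the data shown here, the only measured step (a 3.3-fold higher number from compound 2 to compound 3 (0.52 log units; beyond the scatter)) is modest and changes a larger group, so it bears only loosely, and no measured step tests this exchange. A change of similar or smaller size is expected in this assay, leaning towards a lower number. The expected step is small (a 1.5-fold lower number from compound 3 to compound 4 (0.16 log units; within the scatter)). The estimate for compound 4 is 18000 nM (expected range 7000 nM to 45000 nM).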

Compound 4, concentration for 50% growth inhibition: 12900 nM
Beside the measured number, compound 4's estimate is 1.4-fold (0.14 log units) above it; measured number inside the range.
By their numbers in this assay, from the lowest: compounds 2 and 4 (each within the scatter of the next); then compound 3. At a limit, above all of these: compound 1.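

In this assay, the group on this aromatic carbon can shift the reading: methoxy in place of trifluoromethyl gives a 2.0-fold lower number from compound 3 to compound 4 (0.31 log units; beyond the scatter), a modest step just beyond the scatter. With 4-methoxybenzyl on the nitrogen, the separation from the phenyl analogue seen with 4-(trifluoromethyl)benzyl is no longer resolved, with a 1.6-fold higher number from compound 2 to compound 4 (0.21 log units; within the scatter) for that comparison. Nothing measured here gives a reason for either step.

Open, as far as these compounds go, is how an amine or a carboxylic acid at this place would read. Also open, from the compounds shown here alone, is whether a longer chain between the nitrogen and the aromatic ring would alter the reading.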